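Dimethoxy core amides: nitro for chloro on the anilide ring

A few compounds are considered here, and "the series" means these few. Any claim that something is new, unique, unknown or untested is made for them only; others in the source may bear on it.

Measured so far:
Compound 1, `COc1cc2c(cc1OC)C(CC(=O)Nc1cccc(Cl)c1)CC2`: in a functional assay on the whole organism (strain Wistar) for inhibition, with Rattus norvegicus as the target, read by paw edema, at a dose of 100 mg/kg by the oral route (a lower number here means less inhibition, a higher number more inhibition at the dose given (going by the name of the read-out)), compound 1 gives 35.7%.
Compound 2, `COc1cc2c(cc1OC)C(CC(=O)Nc1ccc(Cl)cc1)CC2`: in this assay compound 2 gives 4.69%.

For the measured compounds named here, two compounds carry a number so far, and compound 2 stands lowest of them; its nearest neighbour is compound 1, and the single measured step, a number 31 percentage points lower from compound 1 to compound 2 (beyond the scatter), shows how far apart the two anilides lie when the chloro moves from one aromatic carbon to another.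

The next compound, compound 3, `COc1cc2c(cc1OC)C(CC(=O)Nc1ccc([N+](=O)[O-])cc1)CC2`, is compound 2 with one exchange: nitro in place of chloro on an aromatic carbon. Going by the values given here, the only measured step concerns where a chloro sits on the anilide ring, not what group occupies that carbon; no step among the measured compounds exchanges chloro for nitro, so nothing measured bears directly on the change from compound 2 to compound 3. The expectation therefore rests on compound 2 alone, whose reading of 4.69% is taken as the anchor, with a wide allowance in either direction.

For compound 3 a value of 10% is estimated, within 0% to 32%. The estimated step of a number 5.3 percentage points higher from compound 2 to compound 3 (within the scatter) is expected to stay within the usual scatter.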

Compound 3, a percentage reported as inhibition, in the whole organism at one dose (the size of the read-out at that dose, not a potency): 10.8%
Compound 3: middle estimate off by 0.8 percentage points, on the low side, and the stated range covers the measured number.
By their numbers in this assay, from the lowest: compounds 2 and 3 (each within the scatter of the next); then compound 1.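

In this assay the exchange of chloro for nitro on the aromatic carbon para to a large group gives a number 6.1 percentage points higher from compound 2 to compound 3 (within the scatter) and so does not separate the two groups at the dose used. For the compounds shown here, this is the first step that replaces the group on the anilide ring instead of moving it, and it adds a second substituent at this carbon alongside chloro in compound 2. At this carbon the read-out therefore gives no sign that the change from chloro to nitro matters, whereas the step from compound 1 to compound 2 turned on where the chloro sits. No evidence at hand bears on what lies behind this result.

The compounds shown leave open whether nitro would behave as chloro does on the aromatic carbon that carries chloro in compound 1, so the reach of this result beyond the one carbon is unknown. They also leave open how an amine, a carboxylic acid or a methoxy group on the carbon para to a large group would read in this assay when set against compound 2 and compound 3.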